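Benzamido in place of cyano on compound 2

The source may report more compounds than this note shows. Statements on the series, on what has been measured and on what is new or still open speak of the compounds shown alone.

Measured in a functional assay on HCT-116 cells (Homo sapiens) for inhibition, read by sulforhodamine B assay, with a stated time of 48 h, tested at 50 uM (a lower number here means less inhibition of growth, a higher number more inhibition of growth at the concentration tested), as follows
compound 1 `COc1ccc([C@@H]2C/C(=N/OCc3cn(-c4ccc(C(=O)c5ccccc5)cc4)nn3)c3cc(CC=C(C)C)c(OC)cc3O2)cc1` gives 52%
compound 2 `COc1ccc([C@@H]2C/C(=N/OCc3cn(-c4ccc(C#N)cc4)nn3)c3cc(CC=C(C)C)c(OC)cc3O2)cc1` gives 50%
compound 3 `COc1ccc([C@@H]2C/C(=N/OCc3cn(-c4ccccc4CO)nn3)c3cc(CC=C(C)C)c(OC)cc3O2)cc1` gives 100%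

Compound 2 shares the low end of these three numbers: the values show a number 2 percentage points lower from compound 1 to compound 2 (within the scatter) and then a number 50 percentage points higher from compound 2 to compound 3 (beyond the scatter) in this assay. Compound 4 `COc1ccc([C@@H]2C/C(=N/OCc3cn(-c4ccc(NC(=O)c5ccccc5)cc4)nn3)c3cc(CC=C(C)C)c(OC)cc3O2)cc1` has benzamido in place of cyano on an aromatic carbon and has yet to be measured. Compound 1 offers the nearest guide: cyano in place of benzoyl on an aromatic carbon gave a number 2 percentage points lower from compound 1 to compound 2 (within the scatter) and suggests little movement. The large step of a number 50 percentage points higher from compound 2 to compound 3 (beyond the scatter) belongs to 2-(hydroxymethyl)phenyl in place of 4-cyanophenyl on an aromatic nitrogen, a different change, and bears less. No step beyond the scatter is expected, the expected change being a number 5 percentage points higher from compound 2 to compound 4 (within the scatter) in this assay. Compound 4 is estimated at 55% within a range of 35% to 80%.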

Compound 4, percent growth inhibition at one concentration: 8%
For compound 4 the middle estimate is 47 percentage points above the measured one, and the stated range ends above it.
By their numbers in this assay, from the lowest: compound 4; then compounds 2 and 1 (each within the scatter of the next); then compound 3.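

On this aromatic carbon, para to a large group, the swap between benzoyl and cyano had suggested a tolerant position, but in this assay benzamido breaks that picture, with a number 42 percentage points lower from compound 2 to compound 4 (beyond the scatter) and a number 44 percentage points lower from compound 1 to compound 4 (beyond the scatter). Compound 1 and compound 4 both carry a six-membered aromatic ring of carbon only here, so that ring alone does not decide the outcome; the amide nitrogen with its hydrogen separates them. Nothing at hand explains the loss. On these data alone, whether it follows the amide link or the attached ring stays open, and acetamido or a plain amine on this carbon would separate the two.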